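The source may hold more compounds than are shown below. What is called first, only, known or untested is meant among the compounds shown, and "the series" means these compounds.

Compound 3 `CCOC(=O)CCCCOc1ccc2c(=O)c(-c3ccc(O)cc3)coc2c1` gives 240 nM in an assay (Cricetulus griseus) for inhibition of aldehyde dehydrogenase, mitochondrial (Homo sapiens) (a lower number here means a stronger inhibitor, a higher number a weaker inhibitor), the highest of the three numbers at hand; compound 2 `CCOC(=O)COc1ccc2c(=O)c(-c3ccc(O)cc3)coc2c1` gives 130 nM and compound 1 `NCCCCCCOc1ccc2c(=O)c(-c3ccc(O)cc3)coc2c1` gives 100 nM. The step of a 2.4-fold higher number from compound 1 to compound 3 (0.38 log units; beyond the scatter) was modest and beyond the scatter, whereas a 1.3-fold higher number from compound 1 to compound 2 (0.11 log units; within the scatter) and a 1.8-fold higher number from compound 2 to compound 3 (0.27 log units; within the scatter) stayed within it. Compound 4 `CC(Oc1ccc2c(=O)c(-c3ccc(O)cc3)coc2c1)C(=O)O` differs from compound 3 by 1-carboxyethyl in place of 4-(ethoxycarbonyl)butyl on an oxygen on an aromatic ring. For the measured compounds named here, no measured step exchanges an ester for a carboxylic acid; the only steps that bear on it are the exchanges at the chain terminus, all of them small. The step of a 1.3-fold lower number from compound 3 to compound 4 (0.12 log units; within the scatter) is therefore expected to stay within the scatter. Compound 4 is estimated at 180 nM, with a range from 60 nM to 600 nM.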

Compound 4, half-maximal inhibitory concentration: 2500 nM
Beside the measured number, compound 4's estimate is 14-fold (1.14 log units) below it; the measured number lies above the stated range.
By their numbers in this assay, from the lowest: compounds 1, 2 and 3 (each within the scatter of the next, the first and the last beyond it); then compound 4.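

In this assay, for the compounds shown here, 1-carboxyethyl on an oxygen on an aromatic ring gives the first large steps at this position, with a 10-fold higher number from compound 3 to compound 4 (1.02 log units; beyond the scatter) and a 19-fold higher number from compound 2 to compound 4 (1.28 log units; beyond the scatter) and a 25-fold higher number from compound 1 to compound 4 (1.40 log units; beyond the scatter) all in the same direction. The 6-aminohexyl, (ethoxycarbonyl)methyl and 4-(ethoxycarbonyl)butyl groups had shown only small differences, so the position is not indifferent to every group placed there. Nothing given here explains the rise. Still open, as far as these compounds go, is whether the carboxylic acid or the branching methyl carries the change. A straight-chain carboxymethyl group or the ethyl ester of 1-carboxyethyl would separate the two.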